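A Dimethylaminopropyl Chain in Place of Hydroxyethyl

This account rests on a few compounds, and the source may have more. Where it says the series, first, only, none or still open, it means among the compounds named here.

The study concerns three compounds that share one core. Compound 1 `Nc1nc2cc(OC(F)(F)F)ccc2s1` bears no chain, compound 2 `N=c1sc2cc(OC(F)(F)F)ccc2n1CCO` bears a 2-hydroxyethyl chain, and compound 3 `CN(C)CCCn1c(=N)sc2cc(OC(F)(F)F)ccc21` bears a 3-(dimethylamino)propyl chain. The read-out is a functional assay on the whole organism with Rattus norvegicus as the target; on this read-out lower numbers stand for an effect already at smaller amounts and higher numbers for an effect only at larger amounts of compound.

For compound 1 this assay reports no number but only a limit, > 10 mg/kg. Compound 2 gives 8 mg/kg in this assay. For the measured compounds named here, that is the only number in the set so far; the other value sits at the limit (the limit of > 10 mg/kg in this assay, at which 1 of the 2 values shown sits), so compound 2 stands as the single measured point from which anything can be said.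

Compound 3 has not yet been measured. It differs from compound 2 in one place ((dimethylamino)methyl in place of hydroxy on a saturated chain carbon, two bonds along the chain from an aromatic nitrogen). Going by the values given here, there is no measured pair in the set that differs in one place, so nothing in the data fixes how large a step of this kind is. The step expected in this assay is therefore a 1.3-fold lower number from compound 2 to compound 3 (0.12 log units; within the scatter), which is taken as no change beyond the usual scatter of repeat measurements. On that basis compound 3 is estimated at 6 mg/kg, with a range from 2 mg/kg to 20 mg/kg.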

Compound 3, dose for half-maximal effect: 9 mg/kg
Estimate against measurement, compound 3: 1.5-fold (0.18 log units) below; measured number inside the range.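

In this assay, putting (dimethylamino)methyl in place of hydroxy, which turns the 2-hydroxyethyl chain into a 3-(dimethylamino)propyl chain, gives a 1.1-fold higher number from compound 2 to compound 3 (0.05 log units; within the scatter). For the compounds shown here, this is the only measured pair in the set that differs in one place, and it gives the first direct reading of a change at this position: the number stays within the usual scatter. On a saturated chain carbon, two bonds along the chain from an aromatic nitrogen, the hydroxy with its hydrogen-bond donor can therefore give way to a group of more heavy atoms with no hydrogen-bond donor, and the read-out shows no change that can be told from repeat measurements. This single pair on a single core does not establish a rule for other chains.

Going by these compounds, compound 1, which bears no chain, has a limit and not a number, so the contribution of a chain as such cannot be sized: the limit of > 10 mg/kg in this assay, at which 1 of the 3 values shown sits. It remains open whether a carboxylic acid, a morpholine ring or a still longer chain carrying the dimethylamino group at this position would move the number beyond the scatter in this assay.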